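A few compounds are considered here, and "the series" means these few. Any claim that something is new, unique, unknown or untested is made for them only; others in the source may bear on it.

Compound 1 `Cc1ccc(NC(=O)c2ccc(CN3CCCN(C)CC3)cc2)cc1-n1cc(-c2cnc3ccnn3c2)cn1` gives 20500 nM in an ADME assay on HEK-293T cells (Homo sapiens) for cytotoxicity, read by CCK-8 assay, with a stated time of 24 h; a higher number here means that more compound is tolerated, a lower number that less compound is tolerated. Compound 2 `Cc1ccc(NC(=O)c2cccc(C(F)(F)F)c2)cc1-n1cc(-c2cnc3cccnn23)cn1` gives 40300 nM in this assay. Compound 3 `Cc1ccc(NC(=O)c2ccc(F)cc2)cc1-n1cc(-c2cnc3cccnn23)cn1` is reported in this assay only as a limit, > 80000 nM. Compound 3 therefore stands at the limit of > 80000 nM in this assay, at which 1 of the 3 values shown sits, without a number of its own. The one measured step among these, an at least 1.9-fold higher number from compound 2 to compound 3 (0.29 log units; that floor lies within the scatter), runs into that limit and its floor sits within the scatter. Compound 4 `CCc1ccc(C(=O)Nc2ccc(C)c(-n3cc(-c4cnc5cccnn45)cn3)c2)cc1` differs from compound 3 by ethyl in place of fluoro on an aromatic carbon. Within the data shown here, no measured step covers this change, and the only neighbouring step gives no direction, so no shift beyond the scatter is expected. Compound 4 is estimated at 60000 nM, with a range of 25000 nM to 150000 nM. This expected estimate means a step of an at least 1.3-fold lower number from compound 3 to compound 4 (0.12 log units; that floor lies within the scatter).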

Compound 4, half-maximal cytotoxic concentration: > 80000 nM
Compound 4: no number, only a limit (the forecaster's own chance of this, stated with the estimate: 40%); middle value at least 1.3-fold (0.12 log units) from the limit.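

Compound 4, with 4-ethylphenyl on the carbonyl, is reported in this assay only as a limit, > 80000 nM, and a second substituent now stands there: the limit of > 80000 nM in this assay, at which 2 of the 4 values shown sit. Fluoro and ethyl on this aromatic carbon therefore have no numbers of their own, and the step between compound 3 and compound 4 cannot be read. Among these compounds, the one readable step is an at least 1.9-fold higher number from compound 2 to compound 4 (0.29 log units; that floor lies within the scatter), and it gives only a floor.

On these data alone, whether an amine, a carboxylic acid or a longer chain on this aromatic carbon would give a measured number stays open. As far as these compounds go, compound 1, at 20500 nM, differs from compound 4 in more than one place, so what sets its value also stays open.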